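The compounds below may be only part of what the source reports. "The series", "measured", "known", "first", "only" and "open" are said of these compounds alone.

Working notes on the series. In an ADME assay on a cell-free system (plasma, Rattus norvegicus) for metabolic stability, read by LC-MS, with a stated time of 1 h, at 37 degrees C, tested at 100 uM (on this read-out higher numbers stand for a more stable compound and lower numbers for a less stable compound), compound 1 (`COc1ccc(C(=O)O)cc1-c1cccc(COc2ccc3c(c2)CN(C2CCCC2)C3=O)c1`) gives 100%, compound 2 (`O=C(O)c1cc(-c2cccc(COc3ccc4c(=O)n(C5CCC5)sc4c3)c2)ccc1Cl`) gives 91% and compound 3 (`CC(C)CCn1sc2cc(OCc3cccc(-c4ccc(Cl)c(C(=O)O)c4)c3)ccc2c1=O`) gives 91%. These three numbers lie within the scatter of each other, so compound 1 does not stand apart from the other two.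

Compound 4 (`O=C(O)c1cc(F)cc(-c2cccc(COc3ccc4c(c3)CN(C3CCCC3)C4=O)c2)c1`) keeps the core of compound 1 and carries 3-carboxy-5-fluorophenyl in place of 5-carboxy-2-methoxyphenyl on an aromatic carbon.

For the measured compounds named here, the only measured step, no change at the digits printed from compound 2 to compound 3 (within the scatter), lies at a different place, on an aromatic nitrogen, so it bears on this change only indirectly. Going by the values given here, no measured step covers the exchange itself. The three measured compounds do, however, stay close together in this assay despite their structural differences, and none goes against this.

The estimated step is a number 6 percentage points lower from compound 1 to compound 4 (within the scatter), with no change expected beyond the scatter and no firm direction. For compound 4 the expected value is 94%, with an estimated range of 82% to 100%.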

Compound 4, percent of the compound remaining: 95%
Compound 4: middle estimate off by 1 percentage points, on the low side; the range from low to high includes it.
By their numbers in this assay, from the lowest: compounds 2, 3, 4 and 1 (each within the scatter of the next).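

At this position on the core of compound 1, 3-carboxy-5-fluorophenyl in place of 5-carboxy-2-methoxyphenyl gives a number 5 percentage points lower from compound 1 to compound 4 (within the scatter) in this assay. For the compounds shown here, this is the first measured step on this aromatic ring rather than on the aromatic nitrogen, and it shows that this exchange, which removes the methoxy group, brings in fluorine and alters the substitution around the carboxylic acid, leaves the read-out within the scatter. Nothing available gives a cause for this result.

Going by these compounds alone, the single step changes these features together, so the contribution of each one stays unresolved. Every compound shown carries a carboxylic acid, so how a methyl ester or a primary amide at that place would read in this assay remains open.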